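From 3-cyanophenyl to 4-(trifluoromethyl)phenyl

The source may report more compounds than this note shows. Statements on the series, on what has been measured and on what is new or still open speak of the compounds shown alone.

Compound 1 `COc1cc(-c2ccnc3cc(-c4ccc(Cl)cc4)nn23)cc(OC)c1OC`: 3070 nM
Compound 2 `COc1cc(-c2ccnc3cc(-c4ccc(C)cc4)nn23)cc(OC)c1OC`: 3 nM
Compound 3 `COc1cc(-c2ccnc3cc(-c4cccc(C#N)c4)nn23)cc(OC)c1OC`: > 10000 nM, a limit

These values come from a functional assay on A549 cells (Homo sapiens) for inhibition, read by CCK-8 assay, with a stated time of 48 h; on this read-out lower numbers stand for stronger inhibition and higher numbers for weaker inhibition. Compound 3 gives only a limit, > 10000 nM, and no number. The unmeasured compound 4 `COc1cc(-c2ccnc3cc(-c4ccc(C(F)(F)F)cc4)nn23)cc(OC)c1OC` carries 4-(trifluoromethyl)phenyl in place of 3-cyanophenyl on an aromatic carbon. Among the compounds with values here, two measured steps bear on this change, read in reverse. Going to 3-cyanophenyl from 4-chlorophenyl gave an at least 3.2-fold higher number from compound 1 to compound 3 (0.51 log units; beyond the scatter), and going to it from 4-methylphenyl gave an at least 3300-fold higher number from compound 2 to compound 3 (3.52 log units; beyond the scatter). Exchanging the two groups at the 4-position of that phenyl gave a 1000-fold lower number from compound 1 to compound 2 (3.01 log units; beyond the scatter), so the size remains quite uncertain. A lower number is expected, and the estimated step in this assay is an at least 10-fold lower number from compound 3 to compound 4 (1.00 log units; beyond the scatter). For compound 4 the estimated value is 1000 nM, with an expected range of 50 nM to 8000 nM.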

Compound 4, half-maximal inhibitory concentration: 2070 nM
For compound 4 the middle estimate is 2.1-fold (0.32 log units) below the measured one, within the range that was stated.
By their numbers in this assay, from the lowest: compound 2; then compounds 4 and 1 (each within the scatter of the next). At a limit, above all of these: compound 3.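

In this assay, 4-(trifluoromethyl)phenyl gives an at least 4.8-fold lower number from compound 3 to compound 4 (0.68 log units; beyond the scatter), a step that holds only as a bound, since compound 3 stands at a limit: the limit of > 10000 nM in this assay, at which 1 of the 4 values shown sits.

Trifluoromethyl sides with chloro rather than methyl, with a 1.5-fold lower number from compound 1 to compound 4 (0.17 log units; within the scatter) but a 690-fold higher number from compound 2 to compound 4 (2.84 log units; beyond the scatter). Among compound 1, compound 2 and compound 4, then, only methyl reaches the low number.

The compounds shown leave open whether an ethyl, a methoxy or an amine in place of methyl would keep that low number. Going by these compounds, it also stays open whether the nitrile itself or its placement on the phenyl separates compound 3 from the others.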